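Oxazole to thiazole on the acid series

This account rests on a few compounds, and the source may have more. Where it says the series, first, only, none or still open, it means among the compounds named here.

Measured in a physicochemical assay for solubility, measured as kinetic solubility, at pH 7.4 (on this read-out lower numbers stand for lower solubility and higher numbers for higher solubility), so far:
- compound 1 `CC(C)c1coc(-c2cccc(CNc3ccc4[nH]nc(C(=O)O)c4c3)c2O)n1` gives 229000 nM
- compound 2 `CN(C)c1noc(-c2cccc(CNc3ccc4[nH]nc(C(=O)O)c4c3)c2)n1` gives 255000 nM
- compound 3 `CN(C)c1noc(-c2cccc(CNc3cnc4nn[nH]c4c3)c2O)n1` gives 590 nM

Compound 1 lies within the scatter of compound 2, and compound 3 sits far under both. Compound 4 `Cc1nc(-c2cccc(CNc3ccc4[nH]nc(C(=O)O)c4c3)c2O)sc1C` has not yet been measured. It carries 4,5-dimethyl-1,3-thiazol-2-yl in place of 4-isopropyl-1,3-oxazol-2-yl on an aromatic carbon. Going by the values given here, no measured pair differs in one place only, so nothing sizes this change directly. The expected result is a small fall that stays within the scatter, the estimated step being a 1.3-fold lower number from compound 1 to compound 4 (0.10 log units; within the scatter) here. For compound 4 the estimated value is 180000 nM, with an expected range from 70000 nM to 300000 nM in this assay.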

Compound 4, solubility: 15000 nM
The estimate for compound 4 lay 12-fold (1.08 log units) above the measured number; the whole stated range lies above it.
By their numbers in this assay, from the lowest: compound 3; then compound 4; then compounds 1 and 2 (each within the scatter of the next).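

In this assay the aromatic carbon ortho to a hydroxy group is not indifferent to the five-membered ring it carries: 4,5-dimethyl-1,3-thiazol-2-yl in place of 4-isopropyl-1,3-oxazol-2-yl gives a 15-fold lower number from compound 1 to compound 4 (1.18 log units; beyond the scatter) on the shared core. This large step comes with no difference in the hydrogen-bond donor or acceptor counts of the two groups. Nothing at hand accounts for the step.

The ring and its alkyl groups change together, so their shares of the step stay unseparated. As far as these compounds go, a 4-isopropyl-1,3-thiazol-2-yl group at this position would divide them, and the effect of an amine on that ring remains open.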